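Allyl oxime ether: stepping from compound 1 to compound 3

A few compounds are considered here, and "the series" means these few. Any claim that something is new, unique, unknown or untested is made for them only; others in the source may bear on it.

Measured so far:
compound 1 `Cc1cc2c(F)c(Oc3ncnc(N)c3/C=N/OCCCO)ccc2[nH]1`: 336 nM
compound 2 `CO/N=C/c1c(N)ncnc1Oc1ccc2[nH]ccc2c1F`: 492 nM

Compound 1 gives the lowest of the two numbers in a functional assay on A-375 cells (Homo sapiens) for antiproliferative activity (on this read-out lower numbers stand for stronger inhibition and higher numbers for weaker inhibition), yet compound 2 sits within the scatter of it, so the two are not separable. Within the data shown here, no single-point step between measured compounds is available to lean on. Compound 3 `C=CCO/N=C/c1c(N)ncnc1Oc1ccc2[nH]c(C)cc2c1F` differs from compound 1 in one place: vinyl in place of 2-hydroxyethyl on a saturated chain carbon bound to an oxygen. Compound 2 carries a methoxy on the same oxime and a core lacking the methyl group, so it cannot be read as a clean precedent for this change. Compound 3 is therefore expected to stay close to compound 1, with a step of a 1.2-fold higher number from compound 1 to compound 3 (0.08 log units; within the scatter) that lies within the scatter rather than beyond it. The estimate for compound 3 in this assay is 400 nM, with a range from 150 nM to 1100 nM.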

Compound 3, half-maximal inhibitory concentration: 21 nM
Beside the measured number, compound 3's estimate is 19-fold (1.28 log units) above it; the whole stated range lies above it.
By their numbers in this assay, from the lowest: compound 3; then compounds 1 and 2 (each within the scatter of the next).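

In this assay, the change of 3-hydroxypropyl to allyl on the oxime gives a 16-fold lower number from compound 1 to compound 3 (1.20 log units; beyond the scatter), a large step beyond the scatter, which shows that the number is highly sensitive to the group at this place on a saturated chain carbon bound to an oxygen. Compound 1 and compound 2 differ in more than one place, so they could not isolate this change, and compound 3 provides its first single-place reading. No measurement at hand bears on why the number falls.

Open, as far as these compounds go, is whether the step follows the double bond of the allyl group or the loss of the terminal hydroxyl, a question a plain propyl chain would address. Also open, from the compounds shown here alone, is how a propargyl group, a longer alkenyl chain or a terminal amine would fare at this place.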